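Chloro to Fluoro on the Fused Ring of Compound 2

A few compounds are considered here, and "the series" means these few. Any claim that something is new, unique, unknown or untested is made for them only; others in the source may bear on it.

Compound 1 `Cc1ccc2nc(Nc3nc(Nc4ccc(S(N)(=O)=O)cc4)ncc3F)sc2c1`: 24500 nM
Compound 2 `Cc1cnc(Nc2ccc(S(C)(=O)=O)cc2)nc1Nc1nc2ccc(Cl)cc2s1`: 4320 nM
Compound 3 `Cc1cnc(Nc2ccc(Cl)cc2)nc1Nc1nc2ccccc2s1`: > 50000 nM

In a functional assay on MCF7 cells (Homo sapiens) for antiproliferative activity, read by MTT assay, with a stated time of 48 h (a higher number here means a weaker inhibitor, a lower number a stronger inhibitor), compound 2 gives 4320 nM, the lowest of the two numbers shown. Compound 1 sits at a higher number, a gap beyond the scatter. Compound 3 returns only a limit, (the limit of > 50000 nM in this assay, at which 1 of the 3 values shown sits), not a number.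

Compound 4 `Cc1cnc(Nc2ccc(S(C)(=O)=O)cc2)nc1Nc1nc2ccc(F)cc2s1` differs from compound 2 in one place: fluoro in place of chloro on an aromatic carbon. Both halogens are single heavy atoms without donors or acceptors, so a small step is expected, perhaps toward a slightly higher number.

The step from compound 2 to compound 4 in this assay is estimated as a 1.6-fold higher number from compound 2 to compound 4 (0.21 log units; within the scatter). Compound 4 is expected to give about 7000 nM, between 2500 nM and 20000 nM.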

Compound 4, half-maximal inhibitory concentration: 3260 nM
Compound 4: middle estimate off by 2.1-fold (0.33 log units), on the high side; measured number inside the range.
By their numbers in this assay, from the lowest: compounds 4 and 2 (each within the scatter of the next); then compound 1. At a limit, above all of these: compound 3.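

In this assay, fluoro in place of chloro on this carbon gives a 1.3-fold lower number from compound 2 to compound 4 (0.12 log units; within the scatter) and so leaves the two compounds indistinguishable. Going by these compounds alone, the earlier compounds include no pair differing only at this position, so this is the first direct reading of it: on this carbon of the fused ring, the two halogens cannot be told apart in this assay. Nothing measured here accounts for that similarity.

The compounds shown leave open how a group unlike a halogen, such as an amine or a carboxylic acid, would read on this carbon. They also leave open whether a longer chain could sit there.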